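The compounds below may be only part of what the source reports. "The series", "measured", "known", "first", "only" and "open" are said of these compounds alone.

Measured so far in a functional assay on the whole organism with Rattus norvegicus as the target; on this read-out lower numbers stand for an effect already at smaller amounts and higher numbers for an effect only at larger amounts of compound:
compound 1 `CC1CCC(=NNc2ccccc2)c2ncc(C(=O)O)c(=O)n21`, where compound 1 gives 1.2 umol/kg;
compound 2 `Cc1ccc(NN=C2CCC(C)n3c2ncc(C(=O)O)c3=O)cc1C`, where compound 2 gives only a limit of the assay, > 100 umol/kg;
compound 3 `CC1CCC(=NNc2ccc(Cl)c(Cl)c2)c2ncc(C(=O)O)c(=O)n21`, where compound 3 likewise gives only a limit of the assay, > 100 umol/kg.

Among the measured compounds shown here, compound 1 thus holds the only proper number in this assay; the two other entries sit at the limit of > 100 umol/kg in this assay, at which 2 of the 3 values shown sit. Both substitutions on the phenyl that were measured are costly: an at least 83-fold higher number from compound 1 to compound 2 (1.92 log units; beyond the scatter), and an at least 83-fold higher number from compound 1 to compound 3 (1.92 log units; beyond the scatter). Between the two substituted analogues the comparison is a step that the two limits leave unreadable from compound 2 to compound 3, so nothing can be said about dimethyl against dichloro beyond the fact that both end at the limit.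

Compound 4 `CC1CCC(=NNc2cc(Cl)ccc2O)c2ncc(C(=O)O)c(=O)n21` carries a different change at the same place: 5-chloro-2-hydroxyphenyl in place of phenyl on an amine nitrogen. For the measured compounds named here, no measured step covers a hydroxyl on this phenyl or this substitution pattern, so the closest guidance is that every measured departure from plain phenyl on the amine nitrogen moved far towards higher numbers. As far as these compounds go, the expectation is therefore a large step in the same direction, a 25-fold higher number from compound 1 to compound 4 (1.40 log units; beyond the scatter), though with wide uncertainty, since the hydroxyl is untested. The estimate for compound 4 in this assay is 30 umol/kg, expected to fall between 3 umol/kg and 150 umol/kg.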

Compound 4, dose for 50% inhibition: > 100 umol/kg
Compound 4: only a limit was reported; the forecaster's own chance of this, stated with the estimate: 40%; middle value at least 3.3-fold (0.52 log units) from the limit.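

In this assay, 5-chloro-2-hydroxyphenyl on the amine nitrogen gives a large loss, with an at least 83-fold higher number from compound 1 to compound 4 (1.92 log units; beyond the scatter). The loss at this position is therefore no longer tied to the 3,4-dimethylphenyl and 3,4-dichlorophenyl groups: a different substitution pattern, with a hydrogen-bond donor and acceptor that phenyl lacks, also ends at a limit of the assay rather than at a number. Among the compounds shown, plain phenyl in compound 1 remains the only group on this nitrogen with a proper number, and the other three entries are limits: the limit of > 100 umol/kg in this assay, at which 3 of the 4 values shown sit.

As far as these compounds go, the steps among compound 2, compound 3 and compound 4 cannot be read, so the order of these three substituted analogues remains unknown, and how far each lies beyond the limit cannot be told. Also open is whether a single small group on the phenyl, such as one fluorine, one methyl or one hydroxyl, would keep a measurable number, and whether an amine or a methoxy group at this place would behave like the groups shown.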